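The source may hold more compounds than are shown below. What is called first, only, known or untested is meant among the compounds shown, and "the series" means these compounds.

In an ADME assay on MDCK-II cells (Canis lupus familiaris) for permeability (a higher number here means that the compound crosses the layer faster, a lower number that the compound crosses the layer more slowly), compound 2 `CCc1cnc(-c2cc(Oc3ccc(S(C)(=O)=O)cc3)cc(OC(C)C)c2)[nH]c1=O` gives 4 10^-6 cm/s and compound 1 `Cc1ccc(NC(=O)c2cc(Oc3ccc(S(C)(=O)=O)cc3)cc(OC(C)C)c2)nc1` gives 4.4 10^-6 cm/s. For the measured compounds named here, these two values lie within the scatter of each other, so compound 2 stands level with the only other number. Compound 3 `COc1cnc(-c2cc(Oc3ccc(S(C)(=O)=O)cc3)cc(OC(C)C)c2)[nH]c1=O` has not yet been measured. The change from compound 2 is methoxy in place of ethyl on an aromatic carbon, para to a large group. Going by the values given here, only one measured step bears on this, a 1.1-fold lower number from compound 1 to compound 2 (0.04 log units; within the scatter), and it lies within the scatter. Among the compounds with values here, that step exchanges a different group, and no measured pair carries this exchange of ethyl for methoxy. No change beyond the scatter is therefore expected in this assay, and no firm direction can be given. The expected step is a 1.1-fold lower number from compound 2 to compound 3 (0.05 log units; within the scatter). For compound 3 the estimated value is 3.6 10^-6 cm/s, with an expected range of 1.8 10^-6 cm/s to 7 10^-6 cm/s.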

Compound 3, apparent permeability: 3.9 10^-6 cm/s
Beside the measured number, compound 3's estimate is 1.1-fold (0.03 log units) below it; low and high end bracket the measured number.
By their numbers in this assay, from the lowest: compounds 3, 2 and 1 (each within the scatter of the next).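

In this assay, for the compounds shown here, the first measured exchange at this position, methoxy in place of ethyl on an aromatic carbon para to a large group, gives a 1.0-fold lower number from compound 2 to compound 3 (0.01 log units; within the scatter). Swapping one hydrogen-bond acceptor into a group of the same heavy-atom count therefore gives no step beyond the scatter here, and the wider exchange on the same aromatic carbon, measured against the amide compound, gives a 1.1-fold lower number from compound 1 to compound 3 (0.05 log units; within the scatter); all three compounds thus stand level in this assay. No measurement shown here accounts for this result.

Ethyl and methoxy are the only two groups shown at this position, so the response to an amine, a carboxylic acid or a longer chain such as butyl stays open. Whether any group here can produce a step beyond the scatter also remains unanswered.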